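A few compounds are considered here, and "the series" means these few. Any claim that something is new, unique, unknown or untested is made for them only; others in the source may bear on it.

Measured so far:
- Compound 1, `Cc1ccc2nc(/N=C3\C(=O)N(CN(C)C)c4ccccc43)sc2c1`: 15600 nM in an ADME assay on 184B5 cells (Homo sapiens) for cytotoxicity, read by sulforhodamine B assay, with a stated time of 48 h; a lower number here means a stronger inhibitor of growth, a higher number a weaker inhibitor of growth
- Compound 2, `CCN(CC)CN1C(=O)/C(=N\c2nc3ccc(C)cc3s2)c2c(Cl)cccc21`: 87800 nM in this assay

Compound 2 shows the highest number of the two, so it is the weaker growth inhibitor, and compound 1 sits at a lower number, a gap that lies beyond the scatter of this assay. Compound 1 and compound 2 differ in more than one place, so no single change can be read from that gap.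

Compound 3, `Cc1ccc2nc(/N=C3\C(=O)N(CN(C)C)c4cccc(Cl)c43)sc2c1`, is not yet measured. It keeps the core of compound 2 and changes one group: dimethylamino in place of diethylamino on a saturated chain carbon bound to an amide-type nitrogen in a ring. Among the compounds with values here, no pair of measured compounds shows this change on its own, so the size of the step has to be guessed. Compound 3 shares its dimethylamino group with compound 1 and its chlorine with compound 2, so a number somewhere between the two measured values seems the most plausible outcome. A modest step toward a lower number is expected, as a 2.2-fold lower number from compound 2 to compound 3 (0.34 log units; beyond the scatter), though it might also stay within the scatter. In this assay compound 3 is estimated at 40000 nM, within a range of 14000 nM to 110000 nM.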

Compound 3, concentration for 50% growth inhibition: 5770 nM
Beside the measured number, compound 3's estimate is 6.9-fold (0.84 log units) above it; measured number outside the range, below it.
By their numbers in this assay, from the lowest: compound 3; then compound 1; then compound 2.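

In this assay, the change from diethylamino to dimethylamino on a saturated chain carbon bound to an amide-type nitrogen in a ring now stands alone with the chlorine kept in place, and it gives a 15-fold lower number from compound 2 to compound 3 (1.18 log units; beyond the scatter). Within the data shown here, the chlorine can also be read alone for the first time: with dimethylamino held constant, chloro in place of hydrogen on an aromatic carbon gives a 2.7-fold lower number from compound 1 to compound 3 (0.43 log units; beyond the scatter), so here the added chlorine goes with stronger growth inhibition rather than weaker. Of these two single changes, the swap of the amine group is the larger step, though no supporting measurement is available to explain either one.

The compounds shown leave open whether the chlorine would give a similar step alongside diethylamino, and so whether the two changes act independently of each other. They also leave open how a ring amine such as morpholine would compare with dimethylamino at this position, and whether a fluorine in place of the chlorine would move the number in the same direction.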